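Swapping 3-methoxyphenyl for furan-2-yl in compound 2

The source may report more compounds than this note shows. Statements on the series, on what has been measured and on what is new or still open speak of the compounds shown alone.

Four related compounds are considered here, and three have been tested in a functional assay on PC-3 cells (Homo sapiens) for inhibition, read by sulforhodamine B assay, with a stated time of 48 h, tested at 50 uM; a higher number here means more inhibition of growth at the concentration tested, a lower number less inhibition of growth. Compound 1 (`COc1cc(/C=C/C(=O)/C=C/c2cccc3ccccc23)ccc1OCc1cn(CCCCCOc2cc(=O)oc3ccccc23)nn1`) is reported as "not active" (no number reported). Compound 3 (`COc1cc(/C=C/C(=O)/C=C/c2ccco2)ccc1OCc1cn(CCCCOc2cc(=O)oc3ccccc23)nn1`) is reported as "not active" (no number reported). Among the compounds with values here, compound 2 (`COc1cccc(/C=C/C(=O)/C=C/c2ccc(OCc3cn(CCOc4cc(=O)oc5ccccc45)nn3)c(OC)c2)c1`) gives 13%, the only number available, so there is no second figure to rank it against. Compound 4 (`COc1cc(/C=C/C(=O)/C=C/c2ccco2)ccc1OCc1cn(CCOc2cc(=O)oc3ccccc23)nn1`) has not yet been measured. It differs from compound 2 by a single change: furan-2-yl in place of 3-methoxyphenyl on a double-bonded chain carbon bound to a double-bonded chain carbon. Furan-2-yl replaces 3-methoxyphenyl on a double-bonded chain carbon bound to a double-bonded chain carbon. Within the data shown here, no measured pair of compounds shows what a single change does, so any forecast is loose. Compound 3 also carries furan-2-yl and is reported as "not active" (no number reported), which gives no reason to expect a rise in this assay. The expected step is a number 4 percentage points lower from compound 2 to compound 4 (within the scatter), a small fall that stays within the usual scatter. Compound 4 is expected at 9%, with an estimated range of 0% to 22%.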

Compound 4, percent growth inhibition at one concentration: 14%
For compound 4 the middle estimate is 5 percentage points below the measured one; the measured number falls inside the stated range.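

In this assay the exchange of 3-methoxyphenyl for furan-2-yl gives a number 1 percentage points higher from compound 2 to compound 4 (within the scatter) and so the two compounds cannot be told apart. Within the data shown here, this is the first pair that differs in one place only, and it shows that on a double-bonded chain carbon bound to a double-bonded chain carbon, a five-membered aromatic ring with one hetero atom and a six-membered aromatic ring of carbon only read alike. Compound 4 carries furan-2-yl and gives 14%.

Still open, as far as these compounds go, is whether a different group at this place, such as a phenyl ring bearing an amine or a carboxylic acid, would move the number clear of the scatter. Nothing shown here offers an explanation for this result.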